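Methyl for Phenyl on Two Related Cores

The compounds below may be only part of what the source reports. "The series", "measured", "known", "first", "only" and "open" are said of these compounds alone.

Measured compounds:
compound 1 `Cc1cc2nn(-c3ccccc3)c(N)c2c(=O)[nH]1` — -4%
compound 2 `Nc1c2c(=O)[nH]c(-c3ccccc3)cc2nn1-c1ccccc1` — -8%
compound 3 `Cc1cc2nc(-c3ccccc3)nc(N)c2c(=O)[nH]1` — 4%

In an assay on isolated protein for inhibition of serine/threonine-protein kinase Chk2 (Homo sapiens), read by mobility shift assay, tested at 30 uM (on this read-out lower numbers stand for less inhibition and higher numbers for more inhibition at the one concentration tested (going by the name of the read-out)), compound 1 gives -4%, compound 2 gives -8%, and compound 3 gives 4%. All three numbers lie near zero, and compound 3 stands within the scatter of compound 1 while beyond it only relative to compound 2. The difference between the cores of compound 2 and compound 3 is not broken down here.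

Compound 4 `Cc1nc(N)c2c(=O)[nH]c(C)cc2n1` is not yet measured. It differs from compound 3 by methyl in place of phenyl on an aromatic carbon. A change of the same kind, (methyl in place of phenyl on an aromatic carbon), is already measured: the step of a number 4 percentage points higher from compound 2 to compound 1 (within the scatter) stayed within the scatter. The surroundings are not identical, since in one case the site lies on a six-membered aromatic ring with 2 nitrogen, between two ring nitrogen atoms, and in the other next to the ring nitrogen of a ring with 1 nitrogen, so the two changes are the same kind of change, not the same.

Within the data shown here, because the only measured instance gave a number 4 percentage points higher from compound 2 to compound 1 (within the scatter), the expected step from compound 3 to compound 4 is a number 2 percentage points higher from compound 3 to compound 4 (within the scatter), again within the scatter. Compound 4 is therefore estimated at 6%, between -8% and 20%.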

Compound 4, a percentage reported as inhibition, at one concentration (the size of the read-out at that concentration, not a potency): 5%
For compound 4 the middle estimate is 1 percentage points above the measured one; low and high end bracket the measured number.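

In this assay, methyl in place of phenyl on the core of compound 3 gives a number 1 percentage points higher from compound 3 to compound 4 (within the scatter). Set beside the earlier case on the other core, the same change reads alike on both: the same change on two cores in this assay, a number 4 percentage points higher (within the scatter) from compound 2 to compound 1 and a number 1 percentage points higher (within the scatter) from compound 3 to compound 4, 3 percentage points apart, within the scatter of two such steps. This shows that in these two pairs the swap leaves the read-out near zero on either core, but it does not show that the change would carry over in the same way to a compound that inhibits clearly, as all four numbers here lie close to zero, where a step has little room to appear.

The compounds shown leave open whether a different group on that aromatic carbon, such as a carboxylic acid or a longer chain, would move the read-out away from zero. Also open, as far as these compounds go, is what the amino group shared by all four compounds contributes to these results.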